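One chloro back on a weak compound

A few compounds are considered here, and "the series" means these few. Any claim that something is new, unique, unknown or untested is made for them only; others in the source may bear on it.

In a functional assay on UACC-62 cells (Homo sapiens) (a lower number here means a stronger inhibitor of growth, a higher number a weaker inhibitor of growth), compound 1 `O=S(=O)(/C=C/c1ccc(Cl)c(Cl)c1)Cc1ccc(Nc2ncnc3ccccc23)cc1` gives 21000 nM. For compound 2 `O=S(=O)(/C=C/c1ccc(F)cc1F)Cc1ccc(Nc2ncnc3ccccc23)cc1` the assay reports only a limit, > 100000 nM. Compound 3 `O=S(=O)(/C=C/c1ccc(F)cc1Cl)Cc1ccc(Nc2ncnc3ccccc23)cc1` differs from compound 2 by chloro in place of fluoro on an aromatic carbon, ortho to a large group. Among the measured compounds shown here, the one measured step that bears on this, an at least 4.7-fold higher number from compound 1 to compound 2 (0.67 log units; beyond the scatter), exchanged 3,4-dichlorophenyl for 2,4-difluorophenyl and weakened growth inhibition modestly. Restoring one chloro may recover part of that loss, so a modest move towards a lower number is expected. The estimated change is an at least 2.0-fold lower number from compound 2 to compound 3 (0.30 log units; that floor lies within the scatter). Compound 3 is expected at 50000 nM, within a range of 20000 nM to 100000 nM.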

Compound 3, concentration for 50% growth inhibition: 100000 nM
Compound 3: the middle estimate sits 2.0-fold (0.30 log units) below what was measured; low and high end bracket the measured number.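

In this assay, the change to 2-chloro-4-fluorophenyl does not bring growth inhibition back to the level of the 3,4-dichlorophenyl compound: the step is a 4.8-fold higher number from compound 1 to compound 3 (0.68 log units; beyond the scatter). So chloro on this aromatic carbon, ortho to a large group, is not enough by itself to match compound 1. The step from fluoro to chloro on this carbon is a number no higher from compound 2 to compound 3 (the limit leaves the size open), and its size cannot be read. For compound 2 the value is only a limit: the limit of > 100000 nM in this assay, at which 1 of the 3 values shown sits.

Going by these compounds, how a bromo, methoxy or amino group on this same carbon would compare with chloro stays open. So does the question of which chloro of the 3,4-dichlorophenyl group matters for the lower number of compound 1.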